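The source may hold more compounds than are shown below. What is called first, only, known or untested is meant among the compounds shown, and "the series" means these compounds.

Measured in an ADME assay on HEK293 cells (Homo sapiens) for cytotoxicity, with a stated time of 72 h (on this read-out higher numbers stand for an effect only at larger amounts of compound and lower numbers for an effect already at smaller amounts), each value being a limit of the assay:
- compound 1 `Cc1ccc(-c2nc3ccccc3s2)cc1NC(=O)c1cc([N+](=O)[O-])c(N2CCC(C(=O)O)CC2)cc1Cl`: > 25000 nM
- compound 2 `COC(=O)C1CCN(c2cc(Cl)c(C(=O)Nc3cc(-c4nc5ccccc5s4)ccc3C)cc2[N+](=O)[O-])CC1`: > 25000 nM
- compound 3 `COc1ccc(-c2nc3ccccc3s2)cc1NC(=O)c1cc([N+](=O)[O-])c(N2CCC(C(=O)O)CC2)cc1Cl`: > 25000 nM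

Compound 3 has no number, only the limit > 25000 nM. The whole series sits there: the limit of > 25000 nM in this assay, at which 3 of the 3 values shown sit.

Compound 4 `COC(=O)C1CCN(c2cc(Cl)c(C(=O)Nc3cc(-c4nc5ccccc5s4)ccc3OC)cc2[N+](=O)[O-])CC1` replaces carboxy with methoxycarbonyl, methyl in place of hydrogen on an oxygen next to a carbonyl group.

The same change appears as a step that the two limits leave unreadable from compound 1 to compound 2. The other measured step, a step that the two limits leave unreadable from compound 1 to compound 3, gives no size either. The expectation rests on compound 2, whose value > 25000 nM is a limit.

No step beyond the scatter, in either direction, is expected in this assay, and the estimated step is a step that the limit leaves unreadable from compound 3 to compound 4. A report at the limit is the likely outcome. For compound 4 the estimated value is 30000 nM, with an expected range of 14000 nM to 50000 nM.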

Compound 4, half-maximal effective concentration: > 25000 nM
Compound 4 was reported as a limit; the forecaster's own chance of this, stated with the estimate: 85%; the middle value does not contradict the limit.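

Compound 4 gives no readable step against compound 3 or compound 2, and the series stays at one limit: the limit of > 25000 nM in this assay, at which 4 of the 4 values shown sit.

The compounds shown leave open at what concentration any of the four would show an effect, and whether methoxycarbonyl in place of carboxy or methoxy in place of methyl changes it.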